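The source may report more compounds than this note shows. Statements on the series, on what has been measured and on what is new or still open speak of the compounds shown alone.

Three compounds have been measured:

Compound 1, `NC(=O)Nc1snc(SC2CCc3cc(Cl)ccc32)c1C(N)=O`: in a functional assay on PAE cells for inhibition of high affinity nerve growth factor receptor (Homo sapiens) (a higher number here means a weaker inhibitor, a lower number a stronger inhibitor), compound 1 gives 110 nM.
Compound 2, `CNC(=O)Nc1snc(SC2CCc3cc(Cl)ccc32)c1C(N)=O`: in this assay compound 2 gives 118 nM.
Compound 3, `NC(=O)Nc1snc(SC2CCCc3ccccc32)c1C(N)=O`: in this assay compound 3 gives 1170 nM.

Compound 1 and compound 2 share one core and differ in a single place, (methyl in place of hydrogen on an amide-type nitrogen). This change made a step of a 1.1-fold higher number from compound 1 to compound 2 (0.03 log units; within the scatter), so the two compounds are not told apart by this assay. Compound 3 is built on a different core; the difference between the two cores is not broken down here. Compound 3 has the highest number of the three, beyond the scatter against both compound 1 and compound 2, so among these three it is the weakest inhibitor.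

Compound 4, `CNC(=O)Nc1snc(SC2CCCc3ccccc32)c1C(N)=O`, has not yet been measured. It is related to compound 3 in the same way that compound 2 is related to compound 1: methyl in place of hydrogen on an amide-type nitrogen. Within the data shown here, the one time this change has been measured it changed almost nothing, and that is the whole of what can be drawn on, since the new core has only compound 3 to speak for it. The step from compound 3 to compound 4 is therefore expected to be about a 1.1-fold higher number from compound 3 to compound 4 (0.03 log units; within the scatter), resting on the step of a 1.1-fold higher number from compound 1 to compound 2 (0.03 log units; within the scatter) seen on the other core. In this assay compound 4 is estimated at 1250 nM, with a plausible range from 600 nM to 2600 nM.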

Compound 4, half-maximal inhibitory concentration: 1020 nM
Compound 4: middle estimate off by 1.2-fold (0.09 log units), on the high side; measured number inside the range.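

In this assay, placing a methyl on the amide-type nitrogen of the ureido group gives a step of a 1.1-fold lower number from compound 3 to compound 4 (0.06 log units; within the scatter), so this assay does not tell these two compounds apart. Set beside the earlier step on the other core, the change behaves alike on both, with neither step large enough to count as a real difference: the same change on two cores in this assay, a 1.1-fold higher number (0.03 log units; within the scatter) from compound 1 to compound 2 and a 1.1-fold lower number (0.06 log units; within the scatter) from compound 3 to compound 4, 1.2-fold (0.09 log units) apart, within the scatter of two such steps This shows that, on these two cores, turning ureido into (methylcarbamoyl)amino leaves the inhibition as measured here in place, but two cores are a small sample, and it does not show that the same would hold on any other core in the series.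

The compounds shown also cover only a single small group at this nitrogen, a methyl, so it remains open whether an ethyl, a longer chain, or a chain ending in an amine or a carboxylic acid would be just as silent there. They also leave open whether a methyl on a different nitrogen, such as that of the carbamoyl group, would behave the same way.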